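A methyl amide in place of a hydroxylated side chain

The compounds below may be only part of what the source reports. "The series", "measured", "known", "first", "only" and "open" are said of these compounds alone.

Of the compounds shown here, three sharing one core have been measured in an ADME assay for permeability; on this read-out lower numbers stand for lower permeability and higher numbers for higher permeability. Compound 1 `CNC(=O)c1cc(C(=O)N[C@H]2[C@@H]3C[C@@H](O)C[C@@H]32)n([C@@H](C)c2ccccc2)n1` gives 61 nm/s. Compound 2 `CNC(=O)c1cc(C(=O)NCCO)n([C@@H](C)c2ccccc2)n1` gives 59 nm/s, and the step of a 1.0-fold lower number from compound 1 to compound 2 (0.01 log units; within the scatter) does not separate the two. Compound 3 `CNC(=O)c1cc(C(=O)NC(C)CO)n([C@@H](C)c2ccccc2)n1` gives 120 nm/s, the highest of the three numbers, though one of its steps, a 2.0-fold higher number from compound 1 to compound 3 (0.29 log units; within the scatter), lies within the scatter and only its gap to compound 2, a 2.0-fold higher number from compound 2 to compound 3 (0.31 log units; beyond the scatter), stands beyond the scatter.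

Compound 4 `CNC(=O)c1cc(C(=O)NC)n([C@@H](C)c2ccccc2)n1` is the next compound, not yet measured in this assay. It differs from compound 3 at the amide-type nitrogen: methyl in place of 1-(hydroxymethyl)ethyl on an amide-type nitrogen. The group that leaves carries one hydrogen-bond donor and one hydrogen-bond acceptor; the methyl that enters carries none. Of the measured steps, a 2.0-fold higher number from compound 2 to compound 3 (0.31 log units; beyond the scatter) bears most closely on this change, since it also reshaped the chain on that nitrogen, and it was a modest step upward. Compound 4 is therefore expected to show a step of a 2.5-fold higher number from compound 3 to compound 4 (0.40 log units; beyond the scatter) in this assay, and its estimated value is 300 nm/s, with a range from 150 nm/s to 600 nm/s.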

Compound 4, apparent permeability: 280 nm/s
Estimate against measurement, compound 4: 1.1-fold (0.03 log units) above; the range from low to high includes it.
By their numbers in this assay, from the lowest: compounds 2, 1 and 3 (each within the scatter of the next, the first and the last beyond it); then compound 4.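

In this assay, methyl on the amide-type nitrogen gives the highest number of the series, with a 2.3-fold higher number from compound 3 to compound 4 (0.37 log units; beyond the scatter) and with a 4.7-fold higher number from compound 2 to compound 4 (0.68 log units; beyond the scatter) and a 4.6-fold higher number from compound 1 to compound 4 (0.66 log units; beyond the scatter) as well. Methyl is the smallest of the four groups and the only one without oxygen, yet size alone does not order the series: compound 3 stands above compound 2 despite its larger group, and compound 1, with the largest group, is not separated from compound 2. No supporting measurement explains the rise seen with compound 4.

The compounds shown do not separate the loss of the hydroxyl from the loss of chain carbons. An ethyl group or a 2-methoxyethyl chain on the same nitrogen would bear on that question.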